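Trimming the aryl group on a nucleoside: cell growth inhibition

The source may report more compounds than this note shows. Statements on the series, on what has been measured and on what is new or still open speak of the compounds shown alone.

Compound 1 `COc1nc(N)nc2c1c(-c1cc3ccccc3o1)cn2[C@@H]1O[C@H](CO)[C@@H](O)[C@H]1O` gives 25600 nM in an ADME assay on BJ cells (Homo sapiens), read by MTT assay, with a stated time of 72 h; on this read-out higher numbers stand for weaker inhibition and lower numbers for stronger inhibition.
Compound 2 `Nc1nc(N)c2c(-c3cc4ccccc4o3)cn([C@@H]3O[C@H](CO)[C@@H](O)[C@H]3O)c2n1` gives > 100000 nM in this assay.

Among the measured compounds shown here, compound 1 is the only compound with a measured number here. The value given for compound 2 is a limit of the assay, not a number, so the step of an at least 3.9-fold higher number from compound 1 to compound 2 (0.59 log units; beyond the scatter) is known only as a lower bound; the two compounds differ by amino in place of methoxy on an aromatic carbon.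

Compound 3 `COc1nc(N)nc2c1c(-c1ccoc1)cn2[C@@H]1O[C@H](CO)[C@@H](O)[C@H]1O` is not yet measured. It differs from compound 1 as follows: furan-3-yl in place of 1-benzofuran-2-yl on an aromatic carbon. For the measured compounds named here, no measured step involves this kind of change, so the one known step, from methoxy to amino, does not bear on it directly. The one thing the data show is that a single change on this core can push the value past the assay limit (the limit of > 100000 nM in this assay, at which 1 of the 2 values shown sits). For compound 3, the expected value in this assay is 50000 nM, with a range from 15000 nM to 150000 nM. The step that this estimate implies is a 2.0-fold higher number from compound 1 to compound 3 (0.29 log units; within the scatter), expected to lie in the direction of weaker inhibition.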

Compound 3, half-maximal inhibitory concentration: > 100000 nM
Compound 3: a limit, no number; the forecaster's own chance of this, stated with the estimate: 35%; at least 2.0-fold (0.30 log units) between middle value and limit.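

The change of 1-benzofuran-2-yl to furan-3-yl gives an at least 3.9-fold higher number from compound 1 to compound 3 (0.59 log units; beyond the scatter) in this assay, so the aryl group on the five-membered ring matters for this read-out, just as the methoxy group does in the earlier pair. The value of compound 3 is a limit of the assay and not a number, so the step is known only as a lower bound. Compound 1 now stands as the only compound shown with a measured number, and a single change at either of two places on it leads to the same limit: the limit of > 100000 nM in this assay, at which 2 of the 3 values shown sit.

Going by these compounds, what remains open is which part of this change matters, since it both removes the six-membered aromatic ring and replaces a 2-yl attachment with a 3-yl attachment. A furan-2-yl or a phenyl group in the same place could help separate these two parts, but its effect cannot be told from the compounds shown, and neither can any difference between compound 2 and compound 3.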